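Swapping one aryl thiourea for another at the weak end

The compounds below may be only part of what the source reports. "The series", "measured", "known", "first", "only" and "open" are said of these compounds alone.

Three measured compounds share a core: compound 1 `Cc1ccccc1CN1CCc2c(sc(NC(=O)c3ccccc3Cl)c2C(N)=O)C1`, compound 2 `NC(=O)c1c(NC(=O)c2ccccc2Cl)sc2c1CCN(C(=S)Nc1ccccc1I)C2` and compound 3 `COc1ccccc1NC(=S)N1CCc2c(sc(NC(=O)c3ccccc3Cl)c2C(N)=O)C1`. In a functional assay on HeLa cells (Homo sapiens) for antiproliferative activity, with a stated time of 24 h (on this read-out higher numbers stand for weaker inhibition and lower numbers for stronger inhibition), compound 3 gives only a limit of the assay, > 50000 nM. Compound 1 also gives only a limit, > 50000 nM. Compound 2 gives a number, 29000 nM. Two of the three values sit at the same limit (the limit of > 50000 nM in this assay, at which 2 of the 3 values shown sit), so the steps among them are hard to read: an at least 1.7-fold lower number from compound 1 to compound 2 (0.23 log units; that floor lies within the scatter), a step that the two limits leave unreadable from compound 1 to compound 3 and an at least 1.7-fold higher number from compound 2 to compound 3 (0.23 log units; that floor lies within the scatter).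

Compound 4 `NC(=O)c1c(NC(=O)c2ccccc2Cl)sc2c1CCN(C(=S)Nc1c(Cl)cccc1Cl)C2` differs from compound 3 in one place: 2,6-dichlorophenyl in place of 2-methoxyphenyl on an amide-type nitrogen. Going by the values given here, the only measured step that bears on changing the aryl group on this thiourea nitrogen is an at least 1.7-fold higher number from compound 2 to compound 3 (0.23 log units; that floor lies within the scatter), whose size beyond its floor is unknown. Nothing here shows any such change reaching clearly beyond the scatter. Compound 4 is therefore expected to stay near the weak end, at an estimated 40000 nM with a range from 15000 nM to 100000 nM. That estimate means an expected step of an at least 1.2-fold lower number from compound 3 to compound 4 (0.09 log units; that floor lies within the scatter).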

Compound 4, half-maximal inhibitory concentration: 26500 nM
For compound 4 the middle estimate is 1.5-fold (0.18 log units) above the measured one, within the range that was stated.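

In this assay, 2,6-dichlorophenyl in place of 2-iodophenyl on this amide-type nitrogen gives a 1.1-fold lower number from compound 2 to compound 4 (0.04 log units; within the scatter), so these two aryl groups cannot be told apart here. The same group in place of 2-methoxyphenyl gives an at least 1.8-fold lower number from compound 3 to compound 4 (0.27 log units; that floor lies within the scatter), and the full group on the ring amine nitrogen, compared with that of compound 1, gives an at least 1.8-fold lower number from compound 1 to compound 4 (0.27 log units; that floor lies within the scatter). Neither of these two steps has a known full size, because each starts from a limit rather than a number: the limit of > 50000 nM in this assay, at which 2 of the 4 values shown sit.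

On these data alone, whether any change of the aryl group at this position reaches clearly beyond the scatter remains open. Also open, as far as these compounds go, is how the thiourea would behave with an aryl ring carrying an amine or a carboxylic acid.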